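From hydroxy to acetoxy on compound 1

The source may hold more compounds than are shown below. What is called first, only, known or untested is meant among the compounds shown, and "the series" means these compounds.

Compound 1 (`CC1=CC[C@H]2[C@@H]1CC=C(C)[C@@H](CC[C@H]1[C@]3(C)CC[C@H](O)C(C)(C)O[C@H]3CC[C@@]1(C)O)C2(C)C`) is the reference point here. In a functional assay on MCF7 cells (Homo sapiens) for antiproliferative activity, read by MTT assay, with a stated time of 72 h (a lower number here means a stronger inhibitor, a higher number a weaker inhibitor), compound 1 gives > 50000 nM, which is a limit of the assay and not a number. The record for this compound therefore reads (the limit of > 50000 nM in this assay, at which 1 of the 3 values shown sits).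

Two relatives offer real numbers. In this assay compound 2 (`CC(=O)O[C@H]1CC[C@]2(C)[C@H](CC[C@@](C)(O)[C@H]2CC[C@@H]2C(C)=CC[C@H]3[C@H](CC[C@]3(C)OC(C)=O)C2(C)C)OC1(C)C`) gives 39200 nM and compound 3 (`CC1=CC[C@H]2[C@H](CC[C@]2(C)O)C(C)(C)[C@@H]1CC[C@H]1[C@]2(C)CC[C@H](OC(=O)c3ccccc3)C(C)(C)O[C@H]2CC[C@@]1(C)O`) gives 21000 nM. These two values lie within the usual scatter of each other, so they are best read as one level of activity.

Compound 4 (`CC(=O)O[C@H]1CC[C@]2(C)[C@H](CC[C@@](C)(O)[C@H]2CC[C@@H]2C(C)=CC[C@@H]3C(C)=CC[C@@H]3C2(C)C)OC1(C)C`) has not yet been measured. Its change from compound 1 is acetyl in place of hydrogen on an oxygen on a saturated carbon, or hydroxy to acetoxy. Compound 2 also carries acetoxy and stands at 39200 nM, so it is the closest guide available. A modest step towards stronger inhibition is expected in this assay, and the result could still fall at the limit. The estimated change is an at least 1.4-fold lower number from compound 1 to compound 4 (0.15 log units; that floor lies within the scatter), counted from a limit and so only approximate. Compound 4 is expected at about 35000 nM, with an estimated range of 15000 nM to 70000 nM.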

Compound 4, half-maximal inhibitory concentration: 43500 nM
The estimate for compound 4 lay 1.2-fold (0.09 log units) below the measured number; the range from low to high includes it.
By their numbers in this assay, from the lowest: compounds 3, 2 and 4 (each within the scatter of the next, the first and the last beyond it). At a limit, above all of these: compound 1.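

Within the data shown here, compound 4 and compound 1 form the first pair here that differs in one place, so hydroxy to acetoxy on this oxygen can now be read without other changes in the structure. In this assay compound 1 gives > 50000 nM, which is a limit of the assay and not a number. Acetyl in place of hydrogen therefore gives an at least 1.1-fold lower number from compound 1 to compound 4 (0.06 log units; that floor lies within the scatter), so this single pair supports only a floor for the change and does not show that acetoxy clearly improves on hydroxy, and its true size stays unknown: the limit of > 50000 nM in this assay, at which 1 of the 4 values shown sits.

The compounds shown leave open how this same oxygen would respond to a longer chain such as a butanoyl ester, or to a group carrying an amine or a carboxylic acid. They also leave open whether hydroxy to acetoxy would give a step of similar size on a core other than that of compound 1, as one pair cannot settle this.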